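A few compounds are considered here, and "the series" means these few. Any claim that something is new, unique, unknown or untested is made for them only; others in the source may bear on it.

In an ADME assay on RAW264.7 cells (Mus musculus) for cytotoxicity, read by MTT assay, with a stated time of 48 h (a higher number here means a weaker inhibitor, a lower number a stronger inhibitor), compound 2 `O=C(Nc1ccc(NS(=O)(=O)C(F)(F)F)c(Cl)c1)c1cc(C(F)(F)F)cc(C(F)(F)F)c1` stands at the highest of the two numbers recorded so far, giving 136000 nM. Within the data shown here, its only neighbour is compound 1 `O=C(Nc1ccc(NS(=O)(=O)C(F)(F)F)c(Cl)c1)c1cccc(C(F)(F)F)c1`, which in this assay gives 55800 nM. Among the measured compounds shown here, the one step linking them, a 2.4-fold higher number from compound 1 to compound 2 (0.39 log units; beyond the scatter), is a trifluoromethyl in place of hydrogen on an aromatic carbon, a change of a different kind from the one considered next.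

Compound 3 `O=C(Nc1ccc(NS(=O)(=O)C(F)(F)F)c(F)c1)c1cc(C(F)(F)F)cc(C(F)(F)F)c1` differs from compound 2 by fluoro in place of chloro on an aromatic carbon. For the measured compounds named here, no measured step concerns a halogen swap at this position, so the step from compound 1 to compound 2 offers no direct guide to its size or direction. With nothing to indicate a shift, the expectation for this assay is a step from compound 2 to compound 3 that stays within the scatter, a 1.0-fold lower number from compound 2 to compound 3 (0.02 log units; within the scatter). Compound 3 is accordingly estimated at 130000 nM in this assay, with a range from 55000 nM to 310000 nM.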

Compound 3, half-maximal inhibitory concentration: 112000 nM
For compound 3 the middle estimate is 1.2-fold (0.06 log units) above the measured one, and the stated range covers the measured number.
By their numbers in this assay, from the lowest: compounds 1, 3 and 2 (each within the scatter of the next, the first and the last beyond it).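

In this assay the swap of chloro for fluoro, on the aromatic carbon ortho to the ((trifluoromethyl)sulfonyl)amino group, gives a 1.2-fold lower number from compound 2 to compound 3 (0.08 log units; within the scatter) and so stays within the scatter, whereas the added trifluoromethyl gave a 2.4-fold higher number from compound 1 to compound 2 (0.39 log units; beyond the scatter) and lay beyond it. Among these compounds, this is the first reading at this position: with both trifluoromethyl groups of compound 2 held in place, the two halogens cannot be told apart in this cell read-out, and the position tolerates this exchange without a measurable step. Nothing available bears on why the exchange behaves this way, so no cause can be offered.

Going by these compounds, this rests on one pair, so it remains open whether the same exchange would also stay within the scatter on the core of compound 1, which carries a single trifluoromethyl group. Also open, on these data alone, is how the number would respond to a change of another kind at this position, such as hydrogen, a methoxy group, a nitrile or an amine in place of the halogen, since both groups seen here are halogens.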